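Ring size at the chain carbon: four to six

A few compounds are considered here, and "the series" means these few. Any claim that something is new, unique, unknown or untested is made for them only; others in the source may bear on it.

Measured so far, in a functional assay on MCF7 cells (Homo sapiens) for cytotoxicity, read by CellTiter-Glo, with a stated time of 5 days; on this read-out lower numbers stand for stronger inhibition and higher numbers for weaker inhibition:
Compound 1 `O=C(O)/C=C/c1ccc(/C(=C(\c2ccccc2)C(F)F)c2ccc3[nH]ncc3c2)cc1` gives 14 nM.
Compound 2 `O=C(O)/C=C/c1ccc(/C(=C(\c2ccccc2)C2CCC2)c2ccc3[nH]ncc3c2)cc1` gives 1.4 nM.

Within the data shown here, compound 2 holds the lowest number of the two; the only other compound, compound 1, sits beyond the scatter above it, as the step of a 10-fold lower number from compound 1 to compound 2 (1.00 log units; beyond the scatter) shows. Compound 3 `O=C(O)/C=C/c1ccc(/C(=C(\c2ccccc2)C2CCCCC2)c2ccc3[nH]ncc3c2)cc1` differs from compound 2 by cyclohexyl in place of cyclobutyl on a double-bonded chain carbon bound to an aromatic carbon and a double-bonded chain carbon. That earlier step is the only one at this place, and it swapped an open chain for a ring rather than one ring for another, so it is a loose guide. The step is expected to be small, a 1.4-fold higher number from compound 2 to compound 3 (0.15 log units; within the scatter). Compound 3 is therefore estimated at 2 nM, ranging from 0.5 nM to 8 nM.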

Compound 3, half-maximal inhibitory concentration: 64 nM
The estimate for compound 3 lay 32-fold (1.51 log units) below the measured number; the measured number lies above the stated range.
By their numbers in this assay, from the lowest: compound 2; then compound 1; then compound 3.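

In this assay, ring size at this place matters greatly: replacing cyclobutyl with cyclohexyl gives a 46-fold higher number from compound 2 to compound 3 (1.66 log units; beyond the scatter) and shows that these two carbon rings are not interchangeable. Having a ring here does not by itself give a low number either, as replacing the open-chain difluoromethyl group with cyclohexyl gives a 4.6-fold higher number from compound 1 to compound 3 (0.66 log units; beyond the scatter) in the same assay. No measurement offered here explains this loss.

Cyclopentyl, with its five-membered ring, remains an open case. So does a six-membered ring containing oxygen, such as tetrahydropyranyl, which would show whether a ring atom other than carbon changes the outcome.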